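Aryl urea variation on a pyrazole series: compound 4

The source may hold more compounds than are shown below. What is called first, only, known or untested is meant among the compounds shown, and "the series" means these compounds.

Measured so far:
compound 1 `O=C(Nc1cccc(-n2cc(-c3ccncc3)c(-c3ccc(Cl)c(O)c3)n2)c1)Nc1cccc(C(F)(F)F)c1`, 4340 nM
compound 2 `COc1cc(-c2nn(-c3cccc(NC(=O)Nc4cc(C(F)(F)F)cc(C(F)(F)F)c4)c3)cc2-c2ccncc2)ccc1Cl`, 916 nM
compound 3 `O=C(Nc1cccc(-n2cc(-c3ccncc3)c(-c3ccc(Cl)c(O)c3)n2)c1)Nc1ccc(Cl)c(Cl)c1`, 930 nM

In a functional assay on UACC-257 cells (Homo sapiens) for inhibition, read by sulforhodamine B assay, with a stated time of 48 h (a higher number here means a weaker inhibitor of growth, a lower number a stronger inhibitor of growth), compound 2 gives the lowest number of the three; its gap to compound 3 is within the scatter, its gap to compound 1 is beyond it. Compound 4 `COc1cc(-c2nn(-c3cccc(NC(=O)Nc4cccc(C(F)(F)F)c4)c3)cc2-c2ccncc2)ccc1Cl` differs from compound 2 by hydrogen in place of trifluoromethyl on an aromatic carbon. Going by the values given here, no measured step removes a trifluoromethyl outright; the one related step, a 4.7-fold lower number from compound 1 to compound 3 (0.67 log units; beyond the scatter), shows that the 3-(trifluoromethyl)phenyl urea gives a weaker compound than the 3,4-dichlorophenyl urea on the hydroxy core. A modestly higher number is therefore expected, a 2.7-fold higher number from compound 2 to compound 4 (0.44 log units; beyond the scatter). Compound 4 is estimated at 2500 nM, within 900 nM to 7000 nM.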

Compound 4, concentration for 50% growth inhibition: 923 nM
For compound 4 the middle estimate is 2.7-fold (0.43 log units) above the measured one, within the range that was stated.
By their numbers in this assay, from the lowest: compounds 2, 4 and 3 (each within the scatter of the next); then compound 1.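

In this assay the aryl urea tolerates loss of one trifluoromethyl on the core of compound 2: hydrogen in its place gives a 1.0-fold higher number from compound 2 to compound 4 (0.00 log units; within the scatter) and so no change beyond the scatter. With the 3-(trifluoromethyl)phenyl urea held constant, the oxygen substituent does register: methyl in place of hydrogen gives a 4.7-fold lower number from compound 1 to compound 4 (0.67 log units; beyond the scatter) on the shared core. No evidence on hand bears on either step.

As far as these compounds go, whether an amine or a carboxylic acid on that aromatic carbon would shift the number remains open. So does whether the methyl step on the oxygen carries over to the 3,4-dichlorophenyl urea.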